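Chain length on the protected core: notes

The source may report more compounds than this note shows. Statements on the series, on what has been measured and on what is new or still open speak of the compounds shown alone.

Values in a functional assay on MIA PaCa-2 cells (Homo sapiens) for inhibition, read by MTT assay, with a stated time of 72 h; on this read-out higher numbers stand for weaker inhibition and lower numbers for stronger inhibition:
- Compound 1 `CCCCCC/C=C/CCCCCCCCOC[C@H]1NC[C@H](O)[C@@H]1O`: > 100000 nM, a limit and not a number
- Compound 2 `C=CCCCCCCOC[C@@H]1CCCN1C(=O)OC(C)(C)C`: 47100 nM
- Compound 3 `C=CCCCCCCCCCOC[C@@H]1CCCN1C(=O)OC(C)(C)C`: 50300 nM

Among the measured compounds shown here, compound 3 and compound 2 give the only two true numbers so far, and they lie within the scatter of each other. For compound 1 there is only (the limit of > 100000 nM in this assay, at which 1 of the 3 values shown sits), and no step can be read from it.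

Compound 4 `CCCCCCCC/C=C/CCCCCCCCOC[C@@H]1CCCN1C(=O)OC(C)(C)C` has not yet been measured. Its difference from compound 3 is a group of 10 heavy atoms (10 carbon; no ring) in place of a group of 3 heavy atoms (3 carbon; no ring), on a saturated chain carbon, eight bonds along the chain from an oxygen on a saturated carbon. For the measured compounds named here, the one measured step that bears on this change is a 1.1-fold higher number from compound 2 to compound 3 (0.03 log units; within the scatter). There too a larger group replaced a smaller one on the chain, and the numbers did not move beyond the scatter. Going by the values given here, the group entering now is larger than the one in that step, so the step is only a loose guide.

No step beyond the scatter is therefore expected in this assay. The range is kept wide on the upper side, since a limit remains possible. The expected change is a 1.1-fold higher number from compound 3 to compound 4 (0.04 log units; within the scatter). The expected value for compound 4 is 55000 nM, with an estimated range from 25000 nM to 110000 nM.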

Compound 4, half-maximal inhibitory concentration: > 100000 nM
Compound 4 gave a limit, no number; the forecaster's own chance of this, stated with the estimate: 30%; middle value at least 1.8-fold (0.25 log units) away from the limit.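

In this assay compound 4 gives > 100000 nM as a limit and not a number. The step read from that limit is an at least 1.9-fold higher number from compound 3 to compound 4 (0.29 log units; that floor lies within the scatter) and so does not by itself establish a loss of inhibition beyond the scatter, although the true step may be larger than this floor. Still, the change from allyl to the group of 10 carbon atoms, on a saturated chain carbon, eight bonds along the chain from an oxygen on a saturated carbon, is the first change on the protected core to leave no true number, where the earlier chain change stayed within the scatter: the limit of > 100000 nM in this assay, at which 2 of the 4 values shown sit.

The compounds shown leave open at which chain length between compound 3 and compound 4 true numbers end, and whether a fully saturated chain of the same length would also reach the limit. Among the compounds shown here, they also leave open whether an amine or a carboxylic acid on that saturated chain carbon would restore a true number on the shared core, and whether a shorter chain would give any stronger inhibition than the values so far.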